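Methoxy in place of fluoro on the benzyl group of compound 1

A few compounds are considered here, and "the series" means these few. Any claim that something is new, unique, unknown or untested is made for them only; others in the source may bear on it.

Within the data shown here, compound 1 `COc1ccc(N2C(=O)N(Cc3c(F)cc(F)cc3F)c3ccccc3S2(=O)=O)cc1OC` gives 2 nM in an assay on HEK293 cells for displacement of a labelled ligand from Orexin receptor type 2 (Homo sapiens), read by scintillation counting, with a stated time of 90 min (on this read-out lower numbers stand for stronger inhibition and higher numbers for weaker inhibition), one of two numbers so far; its nearest neighbour, compound 2 `COc1ccc(N2C(=O)N(Cc3c(F)cc(F)cc3Cl)c3ccccc3S2(=O)=O)cc1OC`, gives 1 nM, within the scatter of compound 1. Among the measured compounds shown here, the single measured step, a 2.0-fold lower number from compound 1 to compound 2 (0.30 log units; within the scatter), concerns chloro in place of fluoro and does not speak to a methoxy group. Compound 3 `COc1cc(F)c(CN2C(=O)N(c3ccc(OC)c(OC)c3)S(=O)(=O)c3ccccc32)c(F)c1` differs from compound 1 by methoxy in place of fluoro on an aromatic carbon. For the measured compounds named here, with no measured step bearing on this change, no shift beyond the scatter is expected, and the expected step is a 1.5-fold higher number from compound 1 to compound 3 (0.18 log units; within the scatter). Compound 3 is estimated at 3 nM, between 1 nM and 12 nM.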

Compound 3, inhibition constant: 0.501 nM
Beside the measured number, compound 3's estimate is 6.0-fold (0.78 log units) above it; measured number below the stated range.
By their numbers in this assay, from the lowest: compounds 3, 2 and 1 (each within the scatter of the next, the first and the last beyond it).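

Methoxy in place of fluoro, para to a large group and meta to two fluoro groups, is tolerated on the benzyl group in this assay and gives the first step in the series beyond the scatter (a 4.0-fold lower number from compound 1 to compound 3 (0.60 log units; beyond the scatter)). The step between the 2-chloro-4,6-difluorophenyl and 2,6-difluoro-4-methoxyphenyl groups stays within the scatter (a 2.0-fold lower number from compound 2 to compound 3 (0.30 log units; within the scatter)), so those two compounds cannot be ordered. Nothing available accounts for the methoxy step. On these data alone, whether ethoxy, hydroxyl or an amine at this place would match methoxy remains open. So does the effect of methoxy in place of either remaining fluoro group.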